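Cytotoxicity of a biaryl analogue after removing the anilino bridge

The compounds below may be only part of what the source reports. "The series", "measured", "known", "first", "only" and "open" are said of these compounds alone.

Compound 1 `C=C[C@@](C)(/C=C/c1ccc(Nc2ccc(Cl)c(F)c2)cc1)CCC=C(C)C` and compound 2 `C=C[C@@](C)(/C=C/c1ccc(Nc2ccc(Cl)cc2)cc1)CCC=C(C)C` share one core and differ only by a fluoro on an aromatic carbon. In an ADME assay on BJ cells (Homo sapiens) for cytotoxicity, with a stated time of 72 h (on this read-out lower numbers stand for an effect already at smaller amounts and higher numbers for an effect only at larger amounts of compound), compound 1 gives a value that is a limit of the assay, > 36600 nM. In this assay compound 2 likewise gives only a limit, > 36600 nM. The step that the two limits leave unreadable from compound 1 to compound 2 therefore cannot be read, since (the limit of > 36600 nM in this assay, at which 2 of the 2 values shown sit). Compound 2 thus stands at the limit, with no number to place it against.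

Compound 3 `C=C[C@@](C)(/C=C/c1ccc(-c2cccc(Br)c2)cc1)CCC=C(C)C` arises from compound 2 by 3-bromophenyl in place of (4-chlorophenyl)amino on an aromatic carbon. No measured step bears on this change; the only step shown, from a fluoro to a hydrogen, was itself unreadable. Compound 3 is therefore expected to stay at the limit as well, with a step that the limit leaves unreadable from compound 2 to compound 3 meaning no readable step, and its estimate is 40000 nM within 15000 nM to 100000 nM.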

Compound 3, half-maximal effective concentration: > 36600 nM
Compound 3: only a limit was reported; the forecaster's own chance of this, stated with the estimate: 70%; the middle value lies beyond the limit too.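

Within the data shown here, compound 1, compound 2 and compound 3 all give only a limit in this assay, so no step among them can be read: the limit of > 36600 nM in this assay, at which 3 of the 3 values shown sit. The compounds shown leave open whether the fluoro change or the 3-bromophenyl change alters cytotoxicity at all.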